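Pyridinyl in place of dichlorophenyl on a sulfur

The source may report more compounds than this note shows. Statements on the series, on what has been measured and on what is new or still open speak of the compounds shown alone.

Compound 1 `COc1nc2ccc(CSc3ccc(Cl)c(Cl)c3)cc2nc1OC` holds the only numbered result here: in an ADME assay on Vero 76 cells (Chlorocebus sabaeus) for cytotoxicity, read by MTT assay, with a stated time of 96 h (on this read-out higher numbers stand for lower toxicity in this test and lower numbers for higher toxicity in this test), compound 1 gives 75000 nM. Compound 2 `COc1nc2ccc(CSc3ccc4ccccc4c3)cc2nc1OC` gives > 100000 nM, which is a limit of this assay rather than a number (the limit of > 100000 nM in this assay, at which 1 of the 2 values shown sits). Compound 3 `COc1nc2ccc(CSc3ccccn3)cc2nc1OC` differs from compound 1 by pyridin-2-yl in place of 3,4-dichlorophenyl on a sulfur. Among the compounds with values here, no measured step between two compounds is available to guide this change, so the step from compound 1 to compound 3 is expected to be small, within the scatter or slightly upward, a 1.2-fold higher number from compound 1 to compound 3 (0.08 log units; within the scatter). Compound 3 is therefore estimated at 90000 nM, with a range from 45000 nM to 200000 nM.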

Compound 3, half-maximal cytotoxic concentration: > 100000 nM
Compound 3 ended at the assay's limit; the forecaster's own chance of this, stated with the estimate: 40%; middle value at least 1.1-fold (0.04 log units) from the limit.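

In this assay the change to pyridin-2-yl on the sulfur shows an at least 1.3-fold higher number from compound 1 to compound 3 (0.12 log units; that floor lies within the scatter) and gives no sign of a move toward a lower number. Compound 3 gives > 100000 nM as a limit of the assay, not a number. The true size of the step stays hidden because values pile up at this ceiling: the limit of > 100000 nM in this assay, at which 2 of the 3 values shown sit.

Going by these compounds, whether this position tolerates any group without a lower number remains open. A simple alkyl chain or a phenyl ring carrying an amine or a carboxylic acid on the sulfur could test that.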